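The source may hold more compounds than are shown below. What is called first, only, known or untested is meant among the compounds shown, and "the series" means these compounds.

Working notes on the series in an assay on HEK293 cells for positive allosteric modulation of metabotropic glutamate receptor 2 (Rattus norvegicus), read by thallium flux, with a stated time of 2.5 min; on this read-out higher numbers stand for an effect only at larger amounts of compound and lower numbers for an effect already at smaller amounts.

Three compounds carry numbers. Compound 1 `COc1cc(C(=O)O)ccc1OCCCCOc1ccc(C(=O)C(C)C)c(O)c1C` gives 113 nM. Compound 2 `Cc1c(OCCCCOc2ccc(C(=O)O)cc2)ccc(C(=O)CC2CCCC2)c1O` gives 824 nM. Compound 3 `Cc1c(OCCCCOc2ccccc2C(=O)O)ccc(C(=O)CC2CCCC2)c1C` gives 2580 nM. Within this set compound 2 stands at the second highest number: its nearest neighbour is compound 3, whose number lies higher by a gap beyond the usual scatter, and its furthest is compound 1, whose number lies lower by a gap also beyond the scatter. No pair among these three differs in only one place, so no single step is isolated.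

The next compound is compound 4 `Cc1c(OCCCCOCOc2ccc(C(=O)O)cc2)ccc(C(=O)CC2CCCC2)c1O`. Against compound 2 the change is (4-carboxyphenoxy)methyl in place of 4-carboxyphenyl on an oxygen on a saturated carbon. Nothing in the measured set tests a change of this kind, so the expectation rests on the spread of the series alone. The step is expected to be toward a higher number and beyond the scatter, since compound 2 at 824 nM already sits above compound 1 and the series as a whole spans a wide range.

The step from compound 2 to compound 4 is estimated as a 3.0-fold higher number from compound 2 to compound 4 (0.48 log units; beyond the scatter). Compound 4 is expected to give about 2500 nM, with a range from 700 nM to 9000 nM.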

Compound 4, half-maximal effective concentration: 228 nM
Compound 4: the middle estimate sits 11-fold (1.04 log units) above what was measured, outside the stated range (below it).
By their numbers in this assay, from the lowest: compounds 1 and 4 (each within the scatter of the next); then compound 2; then compound 3.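

In this assay, the series now has its first step that changes only one place: (4-carboxyphenoxy)methyl in place of 4-carboxyphenyl on an oxygen on a saturated carbon gives a 3.6-fold lower number from compound 2 to compound 4 (0.56 log units; beyond the scatter) and so moves the read-out toward effect at smaller amounts. This position therefore accepts a larger group without loss on this read-out, with 11 heavy atoms entering where 9 leave and the aromatic ring and its carboxylic acid retained. The entering group adds both carbon and oxygen, so this single step cannot separate the two, and no measurement at hand bears on what lies behind the shift.

The compounds shown leave open whether the inserted oxygen matters or only the greater length, which a plain all-carbon linker of the same length, with a methylene in place of that oxygen, would address. Among the compounds shown here, they also leave open whether the carboxylic acid on the ring is needed at this position, since no compound here carries a primary amide or a tetrazole in its place.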